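From a branched nitrile tail to an amide tail

The source may report more compounds than this note shows. Statements on the series, on what has been measured and on what is new or still open speak of the compounds shown alone.

Of the compounds shown here, three that share one core have been measured in an assay on isolated protein for inhibition of leukotriene B4 receptor 1 (Homo sapiens), tested at 10 uM; a lower number here means less inhibition, a higher number more inhibition at the concentration tested (going by the name of the read-out). Compound 1 `CC(=O)c1cc(CO)c(OCCCCCCC#N)cc1O` gives 40% in this assay. Compound 2 `CC(=O)c1cc(CC(C)O)c(OCCCCC#N)cc1O` gives 10% in this assay. Compound 3 `CCc1cc(C(C)=O)c(O)cc1OCCCCC(C)(C)C#N` gives 79% in this assay. Among these three numbers compound 3 stands highest: the nearest number, that of compound 1, lies far below it and beyond the usual scatter, and the number of compound 2 lies further below still.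

Compound 4 `CCc1cc(C(C)=O)c(O)cc1OCCCCCCC(=O)N(C)C` differs from compound 3 in one place: 2-(dimethylcarbamoyl)ethyl in place of 1-cyano-1-methylethyl on a saturated chain carbon, four bonds along the chain from an oxygen on an aromatic ring. Among the measured compounds shown here, no pair of measured compounds differs only in this place, so there is no measured step to lean on; the three numbers merely show that tails ending in a nitrile span a wide range in this assay. With the branched nitrile gone and an amide tail in its place, a moderate downward step a number 29 percentage points lower from compound 3 to compound 4 (beyond the scatter) is expected, though with considerable uncertainty. Compound 4 is therefore estimated to give 50% in this assay, within a range from 20% to 80%.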

Compound 4, a percentage reported as inhibition, at one concentration (the size of the read-out at that concentration, not a potency): 100%
The estimate for compound 4 lay 50 percentage points below the measured number, and the stated range ends below it.
By their numbers in this assay, from the lowest: compound 2; then compound 1; then compound 3; then compound 4.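

In this assay, among the compounds shown here, the step of a number 21 percentage points higher from compound 3 to compound 4 (beyond the scatter) is the only measured change at this place, on a saturated chain carbon, four bonds along the chain from an oxygen on an aromatic ring. It shows that the tail need not end in a nitrile: here, 2-(dimethylcarbamoyl)ethyl gives a higher number than 1-cyano-1-methylethyl, and the difference lies beyond the usual scatter. No measurement at hand explains why the amide tail gives more inhibition.

This single swap replaces the nitrile with an amide and also changes the size of the group, so the compounds shown cannot separate these two differences. They also leave open how a tail ending in a carboxylic acid, an amine or an unsubstituted amide would behave at this place.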